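Iodo in place of azido: notes on compound 3

The source may report more compounds than this note shows. Statements on the series, on what has been measured and on what is new or still open speak of the compounds shown alone.

Compound 1 (`CCc1cn([C@H]2C[C@H](N=[N+]=[N-])[C@@H](CO)O2)c(=O)[nH]c1=O`) gives > 100 ug/mL in an ADME assay on Huh-7 cells (Homo sapiens) for cytotoxicity, read by XTT assay (a lower number here means that less compound is tolerated, a higher number that more compound is tolerated), and this is a limit of the assay, not a number. Compound 2 (`[N-]=[N+]=N[C@H]1C[C@H](n2cc(Br)c(=O)[nH]c2=O)O[C@@H]1CO`) gives > 100 ug/mL in this assay and this too is a limit. The whole reference point is thus the limit of > 100 ug/mL in this assay, at which 2 of the 2 values shown sit, and no measured number is available to start from.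

Compound 3 (`CCc1cn([C@H]2C[C@H](I)[C@@H](CO)O2)c(=O)[nH]c1=O`) keeps the ethyl group of compound 1 and differs from it in one place, iodo in place of azido on a saturated ring carbon and that is the step followed here. Among the measured compounds shown here, the only measured step is a step that the two limits leave unreadable from compound 1 to compound 2 and it puts bromo in place of ethyl on an aromatic carbon, leaving the azido group untouched. That step offers no size to carry over.

The expectation rests on compound 1 at > 100 ug/mL and on the structural change alone, so no firm size or direction can be argued in this assay and a value near the limit is expected. The estimated change is a number no higher from compound 1 to compound 3 (the limit leaves the size open) and it carries wide uncertainty. For compound 3 the expected value is 100 ug/mL with an estimated range from 40 ug/mL to 200 ug/mL as its span.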

Compound 3, half-maximal cytotoxic concentration: > 100 ug/mL
Compound 3 was reported as a limit (the forecaster's own chance of this, stated with the estimate: 65%); the middle value sits exactly at the limit.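

Compound 1 and compound 3 both sit at the limit of this assay, so no new step can be read from compound 3, and the iodo in place of azido change has no readable size: the limit of > 100 ug/mL in this assay, at which 3 of the 3 values shown sit.

The compounds shown leave open how far each lies past that limit, and whether iodo in place of azido changes the cytotoxicity at all.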